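Series notes: para substituent on the aryl of the triazolopyridine

A few compounds are considered here, and "the series" means these few. Any claim that something is new, unique, unknown or untested is made for them only; others in the source may bear on it.

Measured so far:
compound 1 `CC#C[C@@H](CC(=O)O)c1ccc(OCc2ccc3nc(-c4ccc(OC(F)F)cc4)nn3c2)cc1` — 98 nM
compound 2 `CC#C[C@@H](CC(=O)O)c1ccc(OCc2ccc3nc(-c4ccc(C(C)C)cc4)nn3c2)cc1` — 30 nM

In an assay on cells for agonist activity at Free fatty acid receptor 1 (Rattus norvegicus), read by a beta-galactosidase reporter and beta-arrestin recruitment, with a stated time of 90 min, in the presence of a further agent that is not named here (on this read-out lower numbers stand for an effect already at smaller amounts and higher numbers for an effect only at larger amounts of compound), compound 2 gives 30 nM, the lowest of the two numbers; its nearest neighbour is compound 1 with 98 nM. Compound 3 `CC#C[C@@H](CC(=O)O)c1ccc(OCc2ccc3nc(-c4ccc(OCCOC)cc4)nn3c2)cc1` differs from compound 2 by 2-methoxyethoxy in place of isopropyl on an aromatic carbon. Going by the values given here, the only step that bears on this is a 3.3-fold lower number from compound 1 to compound 2 (0.51 log units; beyond the scatter), where an alkoxy group gave way to isopropyl. The reverse direction, isopropyl to an alkoxy group, is therefore expected to raise the number by a 2.7-fold higher number from compound 2 to compound 3 (0.43 log units; beyond the scatter). For compound 3 the estimate is 80 nM, with a range of 25 nM to 250 nM.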

Compound 3, half-maximal effective concentration: 562 nM
Compound 3: the middle estimate sits 7.0-fold (0.85 log units) below what was measured; measured number above the stated range.
By their numbers in this assay, from the lowest: compound 2; then compound 1; then compound 3.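

In this assay, going by these compounds alone, 2-methoxyethoxy in place of isopropyl on this aromatic carbon gives a 19-fold higher number from compound 2 to compound 3 (1.27 log units; beyond the scatter), the largest step so far. With oxygen attached to the ring in both compounds, 2-methoxyethyl in place of difluoromethyl on that oxygen still gives a 5.7-fold higher number from compound 1 to compound 3 (0.76 log units; beyond the scatter), so the number also depends on what the oxygen carries. No measurement at hand accounts for either step.

The compounds shown leave open whether the rise follows the chain's oxygens or its length. A plain butyl chain or an ethoxy group at this place would help separate the two.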